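Aryl Replacement at the Amide Nitrogen of Compound 1

This account rests on a few compounds, and the source may have more. Where it says the series, first, only, none or still open, it means among the compounds named here.

Measured compounds:
Compound 1, `COc1ccc(-n2nc(C(N)=O)nc2-c2cc(OC)c(OC)c(OC)c2)cc1`: 40%
Compound 2, `CNC(=O)c1nc(-c2cc(OC)c(OC)c(OC)c2)n(-c2ccc(OC)cc2)n1`: 56%
Compound 3, `COc1ccc(-n2nc(C(=O)Nc3ccc(C)cc3)nc2-c2cc(OC)c(OC)c(OC)c2)cc1`: 38%

Three compounds share a core and differ only at an amide-type nitrogen. In a functional assay on the whole organism for inhibition, with Rattus norvegicus as the target, read by paw edema, with stated times of 30 min and 1 h, at a dose of 0.28 mmol/kg by the oral route (on this read-out higher numbers stand for more inhibition at the one dose given (going by the name of the read-out) and lower numbers for less inhibition), compound 1 gives 40%, the second highest of the three numbers. Compound 2 stands above it: a number 16 percentage points higher from compound 1 to compound 2 (beyond the scatter). Compound 3 lies close to compound 1: a number 2 percentage points lower from compound 1 to compound 3 (within the scatter). Between compound 2 and compound 3 the change runs a number 18 percentage points lower from compound 2 to compound 3 (beyond the scatter).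

Compound 4, `COc1ccc(-n2nc(C(=O)Nc3cccc(F)c3)nc2-c2cc(OC)c(OC)c(OC)c2)cc1`, has not been measured. It differs from compound 1 in one place: 3-fluorophenyl in place of hydrogen on an amide-type nitrogen. Among the measured compounds shown here, the step that bears most directly on this is the one from compound 1 to compound 3, where an aryl group also replaced the hydrogen on the same nitrogen and the number barely moved, a number 2 percentage points lower from compound 1 to compound 3 (within the scatter). On that basis the move to compound 4 in this assay is expected to stay within the scatter, no change at the digits printed from compound 1 to compound 4 (within the scatter). Compound 4 is therefore estimated at 40%, with a range from 28% to 52%.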

Compound 4, a percentage reported as inhibition, in the whole organism at one dose (the size of the read-out at that dose, not a potency): 48%
Beside the measured number, compound 4's estimate is 8 percentage points below it; the range from low to high includes it.
By their numbers in this assay, from the lowest: compounds 3, 1, 4 and 2 (each within the scatter of the next, the first and the last beyond it).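

In this assay, a second aryl group on the amide-type nitrogen, 3-fluorophenyl, again gives a step that stays within the scatter: a number 8 percentage points higher from compound 1 to compound 4 (within the scatter). The result also sits within the scatter of both other substituted amides, a number 10 percentage points higher from compound 3 to compound 4 (within the scatter) and a number 8 percentage points lower from compound 2 to compound 4 (within the scatter), so the clear gap seen between compound 2 and compound 3 does not recur, and 3-fluorophenyl cannot be told apart here from either methyl or 4-methylphenyl. No measurement is at hand that would explain these numbers.

Still open, as far as these compounds go, is how a longer chain such as butyl, or a chain ending in an amine, would read at this nitrogen. Also open is whether a carboxylic acid on the phenyl ring would take the number clear of the scatter, and how any of these compounds would read at other doses.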